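Swapping the para substituent on the benzyl ring

A few compounds are considered here, and "the series" means these few. Any claim that something is new, unique, unknown or untested is made for them only; others in the source may bear on it.

Compound 1 `CNc1nc(NCc2ccc(S(C)(=O)=O)cc2)cc(-c2ccccn2)n1`: 36 nM
Compound 2 `CNc1nc(NCc2ccc(Cl)cc2Cl)cc(-c2ccccn2)n1`: 0.8 nM

Of the compounds shown here, two have been measured in a functional assay on HEK293 cells for agonist activity at G-protein coupled receptor 39 (Homo sapiens), read by inositol phosphate accumulation; a higher number here means that more compound is needed for the effect, a lower number that less compound is needed. Compound 1 carries a methylsulfonyl group on its benzyl ring and gives 36 nM, the higher of the two numbers. Compound 2, which carries two chlorines instead, gives 0.8 nM, a difference that lies well beyond the scatter of the measurement, so compound 1 stands as the weaker of the pair.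

Compound 3 `CNc1nc(NCc2ccc(N(C)C(C)=O)cc2)cc(-c2ccccn2)n1` has not been measured yet. It differs from compound 1 in one place: acetyl(methyl)amino in place of methylsulfonyl on an aromatic carbon. Both groups are uncharged, lack a hydrogen-bond donor and sit at the same position of the benzyl ring, so the change is of modest size. Within the data shown here, there is no measured step of this kind to lean on, and the expectation is therefore a step of no more than the scatter, with a slight lean toward a higher number. Compound 3 is estimated at 50 nM, within a range of 10 nM to 250 nM, which corresponds to an expected step of a 1.4-fold higher number from compound 1 to compound 3 (0.14 log units; within the scatter).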

Compound 3, half-maximal effective concentration: 1180 nM
Compound 3: the middle estimate sits 24-fold (1.37 log units) below what was measured; measured number outside the range, above it.
By their numbers in this assay, from the lowest: compound 2; then compound 1; then compound 3.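

In this assay, placing acetyl(methyl)amino instead of methylsulfonyl on this aromatic carbon gives a 33-fold higher number from compound 1 to compound 3 (1.52 log units; beyond the scatter), so the position clearly distinguishes between these two groups. The step arises even though both groups are uncharged, neither has a hydrogen-bond donor, and their sizes are close, with 4 heavy atoms leaving and 5 entering. Such simple counts are therefore a poor guide to the outcome of this change, and no measurement here explains why the number moves so far.

From the compounds shown here alone, it remains open whether the large step comes from the methyl on the nitrogen of the new group, a question that the plain acetylamino group, with its amide hydrogen, would address on the same aromatic carbon. It is also unknown how a methoxy group, a sulfonamide or a carboxylic acid would fare there, and such groups would show whether methylsulfonyl is unusually well tolerated at this position or acetyl(methyl)amino is unusually poorly tolerated.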